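The source may hold more compounds than are shown below. What is called first, only, known or untested is meant among the compounds shown, and "the series" means these compounds.

Measured set in an assay on isolated protein for inhibition of phosphatidylinositol 4,5-bisphosphate 3-kinase catalytic subunit beta isoform (Homo sapiens); a higher number here means a weaker inhibitor, a lower number a stronger inhibitor:
compound 1, `O=[N+]([O-])c1cccc(S(=O)(=O)c2nc(-c3cnn4ccc(Br)cc34)cs2)c1`: 5450 nM
compound 2, `N#Cc1ccc(F)c(S(=O)(=O)c2nc(-c3cnn4ccc(Br)cc34)cs2)c1`: > 1000 nM, a limit of the assay
compound 3, `N#Cc1cc(S(=O)(=O)c2nc(-c3cnn4ccc(Br)cc34)cs2)ccc1F`: > 1000 nM, a limit of the assay

Compound 2 stands at a limit of this assay, not at a number, so its position relative to compound 1 cannot be read. The steps among the measured compounds are a step that the limit leaves unreadable from compound 1 to compound 2, a step that the limit leaves unreadable from compound 1 to compound 3 and a step that the two limits leave unreadable from compound 2 to compound 3, all unreadable because of the limit of > 1000 nM in this assay, at which 2 of the 3 values shown sit. The unmeasured compound 4 has the structure `CN(C)CCN(C)c1ccc(C#N)cc1S(=O)(=O)c1nc(-c2cnn3ccc(Br)cc23)cs1`. Its change from compound 2 is (2-(dimethylamino)ethyl)(methyl)amino in place of fluoro on an aromatic carbon. No measured step exchanges a group of this kind on the sulfonyl-bearing ring, and the steps that do touch that ring carry no readable size, so nothing shown gives a direction for this change. Compound 4 is therefore expected to sit close to the limit of compound 2. The estimate for compound 4 is 2000 nM, with a range from 300 nM to 15000 nM. The step this estimate means, a step that the limit leaves unreadable from compound 2 to compound 4, is expected to be no larger than the scatter, in neither direction, with the limit on compound 2 keeping this expectation loose.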

Compound 4, half-maximal inhibitory concentration: 3560 nM
Estimate against measurement, compound 4: 1.8-fold (0.25 log units) below; low and high end bracket the measured number.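

In this assay, the step to compound 4 from compound 2 cannot be read, because compound 2 stands only at a limit of the assay: the limit of > 1000 nM in this assay, at which 2 of the 4 values shown sit.

The compounds shown leave open whether (2-(dimethylamino)ethyl)(methyl)amino in place of fluoro shifts inhibition in either direction, and how far any change on the sulfonyl-bearing ring moves it.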